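Cyclopropylmethyl in place of cyclopentyl on an aromatic nitrogen

The source may report more compounds than this note shows. Statements on the series, on what has been measured and on what is new or still open speak of the compounds shown alone.

Compound 1 `O=C(CCCCCCn1cc(Nc2ncc3ccn(Cc4ccccc4Cl)c3n2)cn1)NO` — 41.5 nM
Compound 2 `O=C(CCCCCCn1cc(Nc2ncc3ccn(C4CCCC4)c3n2)cn1)NO` — 22 nM

In an assay on isolated protein for inhibition of protein deacetylase HDAC6 (Homo sapiens), with a stated time of 60 min (a lower number here means a stronger inhibitor, a higher number a weaker inhibitor), compound 2 gives 22 nM, while compound 1 gives 41.5 nM, and the step between them is a 1.9-fold lower number from compound 1 to compound 2 (0.28 log units; within the scatter), within the scatter. Compound 3 `O=C(CCCCCCn1cc(Nc2ncc3ccn(CC4CC4)c3n2)cn1)NO` differs from compound 2 by cyclopropylmethyl in place of cyclopentyl on an aromatic nitrogen. Within the data shown here, the only measured step on the same aromatic nitrogen, a 1.9-fold lower number from compound 1 to compound 2 (0.28 log units; within the scatter), stayed within the scatter, so no step beyond the scatter is expected for compound 3 in this assay. Compound 3 is therefore estimated at 25 nM, with a range from 10 nM to 60 nM. This estimate corresponds to an expected step of a 1.1-fold higher number from compound 2 to compound 3 (0.06 log units; within the scatter).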

Compound 3, half-maximal inhibitory concentration: 16 nM
Beside the measured number, compound 3's estimate is 1.6-fold (0.19 log units) above it, and the stated range covers the measured number.
By their numbers in this assay, from the lowest: compounds 3, 2 and 1 (each within the scatter of the next, the first and the last beyond it).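

At this aromatic nitrogen, a 1.4-fold lower number from compound 2 to compound 3 (0.14 log units; within the scatter) stays within the scatter, so this assay does not separate cyclopropylmethyl from cyclopentyl. Across the three compounds, a 2.6-fold lower number from compound 1 to compound 3 (0.41 log units; beyond the scatter) is the first step beyond the scatter, though a modest one, with cyclopropyl in place of 2-chlorophenyl on a saturated chain carbon bound to an aromatic nitrogen. No evidence at hand accounts for either step. The compounds shown leave open how an amine or a carboxylic acid on this nitrogen would fare, and whether a longer chain there would keep the number in this range.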